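Second chloro on the fused core: expected growth inhibition

The compounds below may be only part of what the source reports. "The series", "measured", "known", "first", "only" and "open" are said of these compounds alone.

Of the compounds shown here, two carry numbers so far. Compound 1 `ClCc1ccc(Cn2cnc3c(Cl)ncnc32)cc1` bears a benzyl group with a chloromethyl substituent on a fused core with one chloro group; in a functional assay on NCI/ADR-RES cells (Homo sapiens) for cytotoxicity, read by sulforhodamine B assay, with a stated time of 48 h (on this read-out higher numbers stand for weaker inhibition of growth and lower numbers for stronger inhibition of growth), compound 1 gives 1510 nM. Compound 2 `ClCc1cccc(Cn2cnc3ncnc(Cl)c32)c1` differs from compound 1 only in the substitution pattern of the benzyl ring, and in this assay compound 2 gives 2750 nM. The two numbers fall within the usual scatter of each other, so no order between compound 1 and compound 2 can be read from them, and compound 1 cannot be singled out as the stronger of the pair.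

Compound 3 `ClCc1ccc(Cn2cnc3c(Cl)nc(Cl)nc32)cc1` has not been measured. Relative to compound 1 the change is chloro in place of hydrogen on an aromatic carbon. Going by the values given here, no measured pair shows this change, so nothing measured here fixes the size of the step. The expected step is a 1.3-fold lower number from compound 1 to compound 3 (0.10 log units; within the scatter), small and not clearly beyond the scatter in either direction. Compound 3 is therefore expected to give about 1200 nM in this assay, with a likely range from 400 nM to 3500 nM.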

Compound 3, concentration for 50% growth inhibition: 16600 nM
Compound 3: middle estimate off by 14-fold (1.14 log units), on the low side; measured number above the stated range.
By their numbers in this assay, from the lowest: compounds 1 and 2 (each within the scatter of the next); then compound 3.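

Chloro in place of hydrogen on this aromatic carbon, between two ring nitrogen atoms, is far from a neutral change in this assay: the single added chlorine gives an 11-fold higher number from compound 1 to compound 3 (1.04 log units; beyond the scatter), a large loss of growth inhibition. Going by these compounds alone, compound 1 and compound 2 stand within the scatter of each other, so they gave no sign of a step of this size, and this is the first step to lie beyond the scatter, which marks this carbon of the shared core as a place where one added atom can weaken growth inhibition strongly. The data at hand offer no measurement that bears on the reason for this step.

On these data alone, whether the loss belongs to chloro in particular or to any group on this carbon remains open, since an amine, a methoxy group or a methyl group here would separate those two readings. Also open, as far as these compounds go, is whether the same chloro change carries over to compound 2, with its different substitution pattern, and gives a step of similar size.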